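This account rests on a few compounds, and the source may have more. Where it says the series, first, only, none or still open, it means among the compounds named here.

Three compounds sharing one core were measured in an assay on isolated protein for binding affinity to serine protease 1 (Homo sapiens); on this read-out higher numbers stand for weaker inhibition and lower numbers for stronger inhibition:

compound 1 `N=C(N)c1cccc(CN2CC[C@H](NS(=O)(=O)c3ccc4cnccc4c3)C2=O)c1`: > 2900 nM
compound 2 `N=C(N)c1cccc(CN2CC[C@H](NS(=O)(=O)c3ccc4ccc(N)nc4c3)C2=O)c1`: > 2900 nM
compound 3 `COc1ccc2ccc(S(=O)(=O)N[C@H]3CCN(Cc4cccc(C(=N)N)c4)C3=O)cc2n1`: > 2900 nM

Each of these values is a limit of the measurement rather than a number. Compound 1 therefore stands nowhere in particular on the numbers shown: its value is a limit, the two further values are limits as well, and all three sit at the same point (the limit of > 2900 nM in this assay, at which 3 of the 3 values shown sit). Within the data shown here, the only step between measured compounds that differ in one place, a step that the two limits leave unreadable from compound 2 to compound 3, is itself unreadable, since both of its ends are limits.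

Compound 4 `N=C(N)c1cccc(CN2CC[C@H](NS(=O)(=O)c3cc4nc(Cl)ccc4s3)C2=O)c1` differs from compound 1 in one place: a group of 10 heavy atoms (7 carbon, 1 nitrogen, 1 sulfur, 1 chlorine; one five-membered aromatic ring with 1 hetero atom, one six-membered aromatic ring with 1 hetero atom) in place of a group of 10 heavy atoms (9 carbon, 1 nitrogen; one six-membered aromatic ring of carbon only, one six-membered aromatic ring with 1 hetero atom), on a sulfonyl sulfur. Among the measured compounds shown here, no measured step touches this change; the one step that exists concerns a different part of the core and gives no size. What is expected for a step that the limit leaves unreadable from compound 1 to compound 4 therefore rests only on the fact that all three measured relatives sit at the limit, with no direction or size that can be read. Compound 4 is accordingly expected to give about 6000 nM in this assay, within a wide range from 1500 nM to 30000 nM, and most likely to be reported again only as a limit.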

Compound 4, inhibition constant: > 2900 nM
Compound 4: a limit, no number (the forecaster's own chance of this, stated with the estimate: 70%); the middle value lies beyond the limit too.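

Compound 4 gives only a limit, > 2900 nM, and compound 1 is also a limit, so the step between compound 1 and compound 4 cannot be read. The same holds across the series: the limit of > 2900 nM in this assay, at which 4 of the 4 values shown sit.

Left open is how strongly any of the four compounds actually binds, and whether the groups on the sulfonyl sulfur differ at all.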